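Swapping the aromatic group on the amine: compound 3 to compound 4

The source may report more compounds than this note shows. Statements on the series, on what has been measured and on what is new or still open speak of the compounds shown alone.

Measured compounds:
Compound 1, `C=C1[C@@H](OC(C)=O)C[C@@H]2[C@](C)(CO[Si](C)(C)C(C)(C)C)[C@H](OC(C)=O)CC[C@@]2(C)[C@@H]1C[C@@H](Nc1ccccc1F)C1=CCOC1=O`, 4740 nM
Compound 2, `C=C1[C@@H](OC(C)=O)C[C@@H]2[C@](C)(CO[Si](C)(C)C(C)(C)C)[C@H](OC(C)=O)CC[C@@]2(C)[C@@H]1C[C@@H](Nc1cccc(F)c1)C1=CCOC1=O`, 4560 nM
Compound 3, `C=C1[C@@H](OC(C)=O)C[C@@H]2[C@](C)(CO[Si](C)(C)C(C)(C)C)[C@H](OC(C)=O)CC[C@@]2(C)[C@@H]1C[C@@H](Nc1cccc2ccccc12)C1=CCOC1=O`, 8930 nM

These three share one core and differ only in the aromatic group attached to the amine nitrogen. In a functional assay on KB cells (Homo sapiens) for cytotoxicity, read by sulforhodamine B assay (a lower number here means a stronger inhibitor, a higher number a weaker inhibitor), compound 3 has the highest number of the three, but the steps to both neighbours fall within the scatter: a 1.9-fold higher number from compound 1 to compound 3 (0.28 log units; within the scatter) and a 2.0-fold higher number from compound 2 to compound 3 (0.29 log units; within the scatter). Compound 4, `C=C1[C@@H](OC(C)=O)C[C@@H]2[C@](C)(CO[Si](C)(C)C(C)(C)C)[C@H](OC(C)=O)CC[C@@]2(C)[C@@H]1C[C@@H](Nc1ccc(F)cc1)C1=CCOC1=O`, has not yet been measured; it carries the change (4-fluorophenyl in place of naphthalen-1-yl on an amine nitrogen). The two steps that bear on it run the other way, from a fluorophenyl group to the naphthyl group, and neither left the scatter; the step of a 1.0-fold lower number from compound 1 to compound 2 (0.02 log units; within the scatter) shows that moving the fluorine on the ring changed little. Therefore in this assay compound 4 is expected to land close to compounds 1 and 2, with the step of a 1.9-fold lower number from compound 3 to compound 4 (0.27 log units; within the scatter) expected to stay within the scatter. Compound 4 is estimated at 4800 nM, within a range from 2400 nM to 9600 nM.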

Compound 4, half-maximal inhibitory concentration: 5090 nM
Estimate against measurement, compound 4: 1.1-fold (0.03 log units) below; measured number inside the range.
By their numbers in this assay, from the lowest: compounds 2, 1, 4 and 3 (each within the scatter of the next).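

With 4-fluorophenyl on the amine nitrogen, the set now holds three fluorophenyl groups that differ only in where the fluorine sits, and in this assay they cannot be told apart: a 1.1-fold higher number from compound 1 to compound 4 (0.03 log units; within the scatter) and a 1.1-fold higher number from compound 2 to compound 4 (0.05 log units; within the scatter). The direct step from the two-ring naphthalen-1-yl to this one-ring group, a 1.8-fold lower number from compound 3 to compound 4 (0.24 log units; within the scatter), also stays inside the scatter, so among these four compounds neither change gives a readable difference at this position. Nothing available explains why the numbers sit so close together.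

As far as these compounds go, all four compounds carry a carbon-only aromatic group on this nitrogen, so it remains open whether a carboxylic acid or an amine on the ring, or a plain alkyl chain in place of the ring, would move the number beyond the scatter. From the compounds shown here alone, whether changes elsewhere on the shared core matter also remains open.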